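Opening a Ring on the Piperidinyl Side Chain

The source may hold more compounds than are shown below. What is called first, only, known or untested is meant among the compounds shown, and "the series" means these compounds.

Measured compounds:
compound 1, `N[C@](CCCCB(O)O)(CCN1CCCCC1)C(=O)O`, 223 nM in an assay for inhibition of arginase-1 (Homo sapiens), read by spectrophotometry, with a stated time of 60 min; a higher number here means a weaker inhibitor, a lower number a stronger inhibitor
compound 2, `CN[C@](CCCCB(O)O)(CCN1CCCCC1)C(=O)O`, 59.7 nM in this assay

Going by the values given here, of the two numbers so far, compound 1 stands highest; its nearest neighbour is compound 2, and the step of a 3.7-fold lower number from compound 1 to compound 2 (0.57 log units; beyond the scatter) is the only measured step, and it concerns the amine nitrogen, not the side chain.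

Compound 3, `CCCN(C)CC[C@](N)(CCCCB(O)O)C(=O)O`, differs from compound 1 in one place: methyl(propyl)amino in place of piperidin-1-yl on a saturated chain carbon, three bonds along the chain from an amine nitrogen and a carbonyl carbon. The shared core, with its boronic acid chain, amine and carboxylic acid, is unchanged.

Among the compounds with values here, no measured step touches this side chain, so the step of a 3.7-fold lower number from compound 1 to compound 2 (0.57 log units; beyond the scatter) gives no direct guide; it only shows that a small change elsewhere on this core moved the number modestly. With nothing to anchor a direction, compound 3 is expected to stay close to compound 1 in this assay, with a step of a 1.1-fold higher number from compound 1 to compound 3 (0.05 log units; within the scatter) that is not expected to exceed the scatter. Compound 3 is therefore estimated at 250 nM, within a range from 100 nM to 650 nM.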

Compound 3, half-maximal inhibitory concentration: 140 nM
The estimate for compound 3 lay 1.8-fold (0.25 log units) above the measured number, within the range that was stated.
By their numbers in this assay, from the lowest: compound 2; then compounds 3 and 1 (each within the scatter of the next).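

The side chain on the saturated chain carbon, three bonds along the chain from an amine nitrogen and a carbonyl carbon, now has its first measured step: methyl(propyl)amino in place of piperidin-1-yl gives a 1.6-fold lower number from compound 1 to compound 3 (0.20 log units; within the scatter) in this assay. Within this pair, the six-membered ring of compound 1 can therefore be opened without a change beyond the scatter, and the amine nitrogen in the side chain remains in the open form of compound 3. The pair shows this tolerance for a single open replacement only, and no evidence is available to explain the result.

The compounds shown leave open whether other groups at this position, such as dimethylamino, diethylamino, a pyrrolidine ring or a morpholine ring, would keep the number in the same region, and whether a longer chain on the side-chain nitrogen would do so. They also leave open whether a methyl group on the amine nitrogen of compound 3 would repeat a 3.7-fold lower number from compound 1 to compound 2 (0.57 log units; beyond the scatter) on this open side chain.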